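Amine variation on the shared core: compounds 1 to 3

The source may report more compounds than this note shows. Statements on the series, on what has been measured and on what is new or still open speak of the compounds shown alone.

Measured compounds:
compound 1 `CN(C)c1ccc(/C=C/C(=O)c2ccc(OC(=O)N3CCCC3)cc2O)cc1` — 12.8%
compound 2 `CCN(CC)c1ccc(/C=C/C(=O)c2ccc(OC(=O)N3CCCC3)cc2O)cc1` — 21%

In an assay on cells for inhibition of Amine oxidase [flavin-containing] A (Homo sapiens), read by fluorescence, with a stated time of 30 min, tested at 10 uM (on this read-out lower numbers stand for less inhibition and higher numbers for more inhibition at the one concentration tested (going by the name of the read-out)), compound 1 gives 12.8% and compound 2 gives 21%. Compound 2 holds the higher of the two numbers, yet the step of a number 8.2 percentage points higher from compound 1 to compound 2 (within the scatter) keeps the two within scatter, so no order between them is claimed. Compound 3 `O=C(/C=C/c1ccc(N2CCCC2)cc1)c1ccc(OC(=O)N2CCCC2)cc1O` follows from compound 2 by pyrrolidin-1-yl in place of diethylamino on an aromatic carbon. Among the compounds with values here, the only step bearing on this change is the one from compound 1 to compound 2, an exchange at the same aromatic carbon, and it was small. The expected step is therefore a number 1 percentage points higher from compound 2 to compound 3 (within the scatter), none beyond the scatter. Compound 3 is estimated at 22%, range 5% to 42%.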

Compound 3, a percentage reported as inhibition, at one concentration (the size of the read-out at that concentration, not a potency): 15.2%
Compound 3: the middle estimate sits 6.8 percentage points above what was measured, within the range that was stated.
By their numbers in this assay, from the lowest: compounds 1, 3 and 2 (each within the scatter of the next).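

At the aromatic carbon para to a large group, the amine now carries a five-membered non-aromatic ring, a change that compounds 1 and 2 did not cover. In this assay the ring leaves the read-out within the scatter of both ring-free amines, with a number 5.8 percentage points lower from compound 2 to compound 3 (within the scatter) and a number 2.4 percentage points higher from compound 1 to compound 3 (within the scatter). No supporting finding bears on the cause of this result. Still open, going by these compounds, is whether piperidin-1-yl or morpholin-4-yl at this carbon would give a step beyond the scatter. A primary amine or a methoxy group there also remains untested within the compounds shown.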